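Replacing a Nitrile with a Methylpyrazole on the Shared Core

A few compounds are considered here, and "the series" means these few. Any claim that something is new, unique, unknown or untested is made for them only; others in the source may bear on it.

Measured so far:
Compound 1 `Cc1cc(NNC(=O)Nc2cc(Cl)nc(Cl)c2)ncc1N(C)C` gives 5.3 nM in a functional assay on CHO cells for antagonist activity at sphingosine 1-phosphate receptor 2 (Homo sapiens), read by scintillation counting and GTPgammaS binding, with a stated time of 4 h, in the presence of a further agent that is not named here; a higher number here means a weaker inhibitor, a lower number a stronger inhibitor.
Compound 2 `Cc1cc(NNC(=O)Nc2cc(Cl)nc(Cl)c2)ncc1C#N` gives 7 nM.
Compound 3 `CCOC(=O)c1cc(C)cc(NNC(=O)Nc2cc(Cl)nc(Cl)c2)n1` gives 2.1 nM.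

Compound 2 stands highest of these three numbers in this assay: compound 1 lies nearest, within the scatter, while compound 3 lies furthest, beyond it. Compound 4 `Cc1cc(NNC(=O)Nc2cc(Cl)nc(Cl)c2)ncc1-c1cnn(C)c1` differs from compound 2 by 1-methyl-1H-pyrazol-4-yl in place of cyano on an aromatic carbon. Among the measured compounds shown here, only one measured step touches this position: a 1.3-fold higher number from compound 1 to compound 2 (0.12 log units; within the scatter), which stayed within the scatter. Compound 3 differs from compound 2 at another part of the shared core, so nothing measured shows how a five-membered aromatic ring behaves here. Because a 1.3-fold higher number from compound 1 to compound 2 (0.12 log units; within the scatter) was small, compound 4 is expected to move little, a 1.4-fold lower number from compound 2 to compound 4 (0.15 log units; within the scatter), giving an estimated 5 nM with a range from 1.5 nM to 20 nM.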

Compound 4, half-maximal inhibitory concentration: 3.4 nM
For compound 4 the middle estimate is 1.5-fold (0.17 log units) above the measured one; the range from low to high includes it.
By their numbers in this assay, from the lowest: compounds 3, 4, 1 and 2 (each within the scatter of the next, the first and the last beyond it).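

Among the compounds shown here, this position tolerates a much larger group than the earlier compounds showed: 1-methyl-1H-pyrazol-4-yl brings a five-membered aromatic ring and 6 heavy atoms where cyano had 2, with a 2.1-fold lower number from compound 2 to compound 4 (0.31 log units; beyond the scatter). Set against dimethylamino, the same ring gives a 1.6-fold lower number from compound 1 to compound 4 (0.19 log units; within the scatter), so those two groups cannot be told apart. No measurement at hand explains either step.

Still open, as far as these compounds go, is whether a phenyl ring or a pyrazole without its methyl group would do as well here. A carboxylic acid at this position also remains untested in the compounds shown.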